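A few compounds are considered here, and "the series" means these few. Any claim that something is new, unique, unknown or untested is made for them only; others in the source may bear on it.

Working notes on the series. In an ADME assay on microsomes from liver (Homo sapiens) for metabolic stability, read by LC-MS, using NADPH, with stated times of 5 min and 30 min, tested at 1 uM (a lower number here means slower removal, a higher number faster removal of the compound), compound 1 (`O=C(Nc1ccccc1)c1cnc(NCc2c(F)ccc3c2CCO3)n2cnnc12`) gives 14 mL.min-1.g-1. Compound 2 (`C[C@@H]1CC(=O)N(c2cnc(NCc3c(F)ccc4c3CCO4)n3cnnc23)C1`) reads < 3 mL.min-1.g-1, which is a limit and not a number. Compound 3 (`O=C(Nc1cnc(NCc2c(F)ccc3c2CCO3)n2cnnc12)c1cccnc1`) reads < 3 mL.min-1.g-1, which is also only a limit. Compound 3 therefore has no exact position in the series, and it stands at the limit of < 3 mL.min-1.g-1 in this assay, at which 2 of the 3 values shown sit.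

Compound 4 (`Fc1ccc2c(c1CNc1ncc(Nc3ccccc3)c3nncn13)CCO2`) differs from compound 3 by phenyl in place of (pyridin-3-yl)carbonyl on a nitrogen on an aromatic ring. Compound 4 thus carries phenyl where compound 3 carries (pyridin-3-yl)carbonyl.

Among the measured compounds shown here, no measured step makes this exact change. The nearest guide is an at least 4.6-fold lower number from compound 1 to compound 3 (0.66 log units; beyond the scatter), where ((pyridin-3-yl)carbonyl)amino replaces phenylcarbamoyl. Also relevant is an at least 4.6-fold lower number from compound 1 to compound 2 (0.66 log units; beyond the scatter), where 4-methyl-2-oxopyrrolidin-1-yl replaces phenylcarbamoyl. The remaining comparison, a step that the two limits leave unreadable from compound 2 to compound 3, gives no usable size. Compound 4 carries a phenyl ring, as compound 1 does at 14 mL.min-1.g-1, so a return towards that level is expected, though this rests on very few compounds. The expected change is an at least 4.6-fold higher number from compound 3 to compound 4 (0.66 log units; beyond the scatter), an increase in this assay of about the size of those two steps and beyond the scatter. For compound 4 the estimated value is 14 mL.min-1.g-1, with an expected range of 5 mL.min-1.g-1 to 40 mL.min-1.g-1.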

Compound 4, intrinsic clearance in microsomes: 20 mL.min-1.g-1
For compound 4 the middle estimate is 1.4-fold (0.15 log units) below the measured one; low and high end bracket the measured number.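

In this assay, the amide link in compound 1 is not needed for the higher reading at this position: the step to anilino is a 1.4-fold higher number from compound 1 to compound 4 (0.15 log units; within the scatter). Phenyl in place of (pyridin-3-yl)carbonyl on the nitrogen gives an at least 6.6-fold higher number from compound 3 to compound 4 (0.82 log units; beyond the scatter), and anilino in place of 4-methyl-2-oxopyrrolidin-1-yl on the aromatic carbon gives an at least 6.6-fold higher number from compound 2 to compound 4 (0.82 log units; beyond the scatter). Across these four compounds, the two with a carbon-only aromatic ring in this substituent, compound 1 and compound 4, give the higher readings with or without a carbonyl, while compound 2 and compound 3, which lack that ring, sit at the limit; none of the four goes against this, though it rests on very few compounds.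

The step between compound 2 and compound 3 cannot be read, and both stand only as limits: the limit of < 3 mL.min-1.g-1 in this assay, at which 2 of the 4 values shown sit. Compound 3 differs from compound 4 by both a carbonyl and a ring nitrogen, so pyridin-3-ylamino and benzoylamino groups at this place would be needed to separate the two.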